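The source may hold more compounds than are shown below. What is called first, only, known or untested is meant among the compounds shown, and "the series" means these compounds.

In an ADME assay on Caco-2 cells (Homo sapiens) for permeability, in the apical to basolateral direction (on this read-out higher numbers stand for higher permeability and lower numbers for lower permeability), compound 3 `C=C(C)C(=O)N1CCC(CN(C2Cc3cc(C#N)ccc3N(Cc3cncn3C)C2)S(=O)(=O)c2ccccn2)CC1` gives 0.5 10^-6 cm/s. Compound 1 `CCC(=O)N1CCC(CN(C2Cc3cc(C#N)ccc3N(Cc3cncn3C)C2)S(=O)(=O)c2ccccn2)CC1` gives 0.5 10^-6 cm/s, and compound 2 `Cn1cncc1CN1CC(N(CC2CCN(C(=O)NC(C)(C)C)CC2)S(=O)(=O)c2ccccn2)Cc2cc(C#N)ccc21` gives 0.6 10^-6 cm/s; compound 3 thus stands level with compound 1, and together they hold the lowest of the three numbers, while compound 2 sits within the scatter of both. Compound 4 `CCNC(=O)N1CCC(CN(C2Cc3cc(C#N)ccc3N(Cc3cncn3C)C2)S(=O)(=O)c2ccccn2)CC1` differs from compound 3 by ethylamino in place of 1-methylethenyl on a carbonyl carbon. Going by the values given here, two measured steps bear on this position: a 1.2-fold higher number from compound 1 to compound 2 (0.08 log units; within the scatter) and a 1.2-fold lower number from compound 2 to compound 3 (0.08 log units; within the scatter). Both stayed within the scatter, and compound 2 already carries an amino group on that carbonyl carbon. No step beyond the scatter is therefore expected in this assay. Compound 4 is expected to give 0.5 10^-6 cm/s, between 0.3 10^-6 cm/s and 1 10^-6 cm/s. That estimate means no change at the digits printed from compound 3 to compound 4 (within the scatter).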

Compound 4, apparent permeability: 0.6 10^-6 cm/s
Compound 4: middle estimate off by 1.2-fold (0.08 log units), on the low side; the range from low to high includes it.
By their numbers in this assay, from the lowest: compounds 1, 3, 2 and 4 (each within the scatter of the next).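

In this assay, the ethylamino group on the carbonyl carbon gives a 1.2-fold higher number from compound 3 to compound 4 (0.08 log units; within the scatter), and the other two comparisons give a 1.2-fold higher number from compound 1 to compound 4 (0.08 log units; within the scatter) and no change at the digits printed from compound 2 to compound 4 (within the scatter). Ethyl in place of tert-butyl on the amide-type nitrogen therefore adds a third kind of group at this carbonyl carbon without a step beyond the scatter. Going by these compounds alone, the hydrogen-bond donor counted for ethylamino likewise comes with no such step. Nothing measured here accounts for how close these numbers stay. From the compounds shown here alone, whether a carboxylic acid or a primary amine on a longer chain at this carbonyl carbon would move the number beyond the scatter remains open.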